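Chloro to hydrogen on the benzyl ether: cytotoxicity notes

A few compounds are considered here, and "the series" means these few. Any claim that something is new, unique, unknown or untested is made for them only; others in the source may bear on it.

Working notes on the series in an ADME assay on HEL cells (Homo sapiens) for cytotoxicity, with a stated time of 3 days; a higher number here means that more compound is tolerated, a lower number that less compound is tolerated. Compound 1 `CCC1(Cc2ccccc2)OS(=O)(=O)C=C1OCCCCc1ccccc1` has been measured in this assay, and its value of >= 20000 nM is a limit of the assay, not a number. Compound 2 `CCCC1(Cc2ccccc2)OS(=O)(=O)C=C1OCc1ccccc1` is also measured, and its value of >= 400000 nM is again a limit of the assay. Compound 3 `CCC1(Cc2ccccc2)OS(=O)(=O)C=C1OCc1cccc(Cl)c1` stands at >= 20000 nM in this assay, once more a limit and not a number. Going by the values given here, all three values are therefore limits, and the single one-change step, a step that the two limits leave unreadable from compound 1 to compound 3, cannot be read for size. Compound 4 `CCC1(Cc2ccccc2)OS(=O)(=O)C=C1OCc1ccccc1` has not yet been measured; it differs from compound 3 as follows: hydrogen in place of chloro on an aromatic carbon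

Among the compounds with values here, no measured step bears on this change. Compound 3 sits at the limit of >= 20000 nM in this assay, at which 2 of the 3 values shown sit, shared with compound 1, while compound 2 sits at the limit of >= 400000 nM in this assay, at which 1 of the 3 values shown sits. With nothing readable, no shift beyond the scatter is expected, and the result is expected to be a limit again. Compound 4 is estimated in this assay at 30000 nM, within 15000 nM to 400000 nM. The step this estimate implies is expected to be a step that the limit leaves unreadable from compound 3 to compound 4.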

Compound 4, minimum cytotoxic concentration: >= 50000 nM
Compound 4 gave a limit, no number; the forecaster's own chance of this, stated with the estimate: 85%; middle value at least 1.6-fold (0.22 log units) away from the limit.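

Compound 4 gives >= 50000 nM as a limit of the assay and not a number. Compound 1, compound 2 and compound 3 also stand at limits, so none of the steps to compound 4 can be read for size. The compounds shown leave open whether hydrogen in place of chloro shifts the minimum cytotoxic concentration at all.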